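Methoxy Enters the Phenyl Ring of Compound 2

A few compounds are considered here, and "the series" means these few. Any claim that something is new, unique, unknown or untested is made for them only; others in the source may bear on it.

Compound 2 `CC(=O)OC[C@H]1O[C@H](OC[C@@H](Cn2cc(CN(c3nc(-c4ccccc4)no3)C3CCCCC3)nn2)OC(C)=O)C=C[C@@H]1OC(C)=O` is one of two measured compounds. In an ADME assay on RAW264.7 cells (Mus musculus) for cytotoxicity, read by MTT assay, with a stated time of 48 h (a higher number here means that more compound is tolerated, a lower number that less compound is tolerated), compound 2 gives 28.6 ug/mL, and compound 1 `CC(=O)OC[C@H]1O[C@H](OC[C@@H](Cn2cc(CN(c3nc(-c4cccc(C)c4)no3)C3CCCCC3)nn2)OC(C)=O)C=C[C@@H]1OC(C)=O` gives 46.4 ug/mL; the two numbers lie within the scatter of each other. For the measured compounds named here, the one measured step, a 1.6-fold lower number from compound 1 to compound 2 (0.21 log units; within the scatter), altered the same six-membered ring that changes now. Compound 3 `COc1ccc(-c2noc(N(Cc3cn(C[C@H](CO[C@@H]4C=C[C@H](OC(C)=O)[C@@H](COC(C)=O)O4)OC(C)=O)nn3)C3CCCCC3)n2)cc1` differs from compound 2 by methoxy in place of hydrogen on an aromatic carbon. Because a 1.6-fold lower number from compound 1 to compound 2 (0.21 log units; within the scatter) stayed within the scatter, the new step is expected to stay within it too, with the estimated change a 1.2-fold higher number from compound 2 to compound 3 (0.09 log units; within the scatter). Compound 3 is estimated at 35 ug/mL, ranging from 17 ug/mL to 70 ug/mL.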

Compound 3, half-maximal cytotoxic concentration: 86.3 ug/mL
Compound 3: the middle estimate sits 2.5-fold (0.39 log units) below what was measured, and the stated range ends below it.
By their numbers in this assay, from the lowest: compounds 2, 1 and 3 (each within the scatter of the next, the first and the last beyond it).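

In this assay, the step of a 3.0-fold higher number from compound 2 to compound 3 (0.48 log units; beyond the scatter) is the first shown to pass beyond the scatter, so a single methoxy on an aromatic carbon, para to a large group, can move this read-out clearly. The change of ring substituent, a 1.9-fold higher number from compound 1 to compound 3 (0.27 log units; within the scatter), does not separate 4-methoxyphenyl from 3-methylphenyl. Nothing available explains the shift. Still open, from the compounds shown here alone, is whether this effect is specific to methoxy, or whether a hydroxyl, a fluorine or an amine at this same place would move the number as far.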